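This account rests on a few compounds, and the source may have more. Where it says the series, first, only, none or still open, it means among the compounds named here.

The series shares the core of compound 1 `Nc1cc(N)c2nc(-c3ccccc3)c(Oc3ccc(Cl)c(Cl)c3)nc2c1`, with the group attached beside the phenyl-bearing ring varied across the set. In a functional assay on M14 cells (Homo sapiens) for inhibition, read by sulforhodamine B assay, with a stated time of 48 h (a lower number here means a stronger inhibitor of growth, a higher number a weaker inhibitor of growth), compound 1 gives 70800 nM, the higher of the two numbers recorded. Compound 3 `COc1cc(CNc2nc3cc(N)cc(N)c3nc2-c2ccccc2)cc(OC)c1OC` gives 18200 nM in this assay, a gap beyond the scatter. Compound 2 `CCOC(=O)[C@H](CCC(=O)O)NC(=O)c1ccc(Sc2nc3cc(N)cc(N)c3nc2-c2ccccc2)cc1` returns only a limit in this assay, < 100000 nM; this is the limit of < 100000 nM in this assay, at which 1 of the 3 values shown sits. Compound 4 `Nc1cc(N)c2nc(-c3ccccc3)c(NCc3ccc(F)cc3)nc2c1` is not yet measured in this assay. It differs from compound 1 by (4-fluorobenzyl)amino in place of 3,4-dichlorophenoxy on an aromatic carbon. Going by the values given here, no step between two measured compounds that differ in this one place is available, so the expectation rests on compound 3, whose lower number 18200 nM comes with a substituted benzylamino group in place of the aryloxy linkage. The change is expected to lower the number, a 2.8-fold lower number from compound 1 to compound 4 (0.45 log units; beyond the scatter), beyond the scatter but not by a wide margin, since compound 4 lacks the trimethoxy pattern of compound 3. For compound 4 the expected value in this assay is 25000 nM, with a range from 8000 nM to 80000 nM.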

Compound 4, concentration for total growth inhibition: 56200 nM
Estimate against measurement, compound 4: 2.2-fold (0.35 log units) below; measured number inside the range.
By their numbers in this assay, from the lowest: compound 3; then compounds 4 and 1 (each within the scatter of the next).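

In this assay, this aromatic carbon next to the ring nitrogen now has a direct one-place comparison, a 1.3-fold lower number from compound 1 to compound 4 (0.10 log units; within the scatter), with (4-fluorobenzyl)amino in place of 3,4-dichlorophenoxy. The earlier compounds shown here offered no such pair: here, two groups of equal heavy-atom count, the entering one carrying a hydrogen-bond donor that the leaving one lacks, give values within the scatter of each other. No measured property among the data bears on this step.

The linking atoms and the ring substituents change together in this step, so their separate contributions remain unresolved. The compounds shown leave open how an unsubstituted benzylamino group, a 3,4-dichlorobenzylamino group or a longer chain such as phenethylamino would read at this position.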